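Permeability Holds Across a Phenoxy-to-Alkyl Exchange

A few compounds are considered here, and "the series" means these few. Any claim that something is new, unique, unknown or untested is made for them only; others in the source may bear on it.

Compound 1 `COc1ccc(Oc2ccc3c(NCCCNCc4cccc(OC)c4O)ccnc3c2)cc1` and compound 2 `COc1cccc(CNCCCNc2ccnc3cc(Oc4ccc(F)cc4)ccc23)c1O` were examined in an ADME assay for permeability, using PAMPA, with a stated time of 30 min, at pH 7.4; a lower number here means that the compound crosses the layer more slowly, a higher number that the compound crosses the layer faster. Going by the values given here, compound 1 gives 317 10^-6 cm/s, and compound 2 gives 317 10^-6 cm/s; the single step of no change at the digits printed from compound 1 to compound 2 (within the scatter) involved a fluoro in place of methoxy on an aromatic carbon. Compound 2 therefore stands level with compound 1. Compound 3 `CCC(CC)c1ccc2c(NCCCNCc3cccc(OC)c3O)ccnc2c1` differs from compound 2 by pentan-3-yl in place of 4-fluorophenoxy on an aromatic carbon. Among the compounds with values here, only that one earlier step bears on this change, and it showed no movement, so no step beyond the scatter is expected in this assay. Compound 3 is expected to give 300 10^-6 cm/s, within 150 10^-6 cm/s to 600 10^-6 cm/s, a step of a 1.1-fold lower number from compound 2 to compound 3 (0.02 log units; within the scatter).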

Compound 3, apparent permeability: 23 10^-6 cm/s
For compound 3 the middle estimate is 13-fold (1.12 log units) above the measured one; measured number below the stated range.
By their numbers in this assay, from the lowest: compound 3; then compounds 1 and 2 (each within the scatter of the next).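

The earlier step showed that exchanging the substituent on the outer aromatic ring leaves this assay unmoved, but it did not test replacing the whole aryloxy group at this position. That replacement does register: a 14-fold lower number from compound 2 to compound 3 (1.14 log units; beyond the scatter) came with pentan-3-yl in place of 4-fluorophenoxy, and a 14-fold lower number from compound 1 to compound 3 (1.14 log units; beyond the scatter) came with pentan-3-yl in place of 4-methoxyphenoxy. No measurement at hand accounts for this difference.

The compounds shown leave open whether the aromatic ring or the linking oxygen matters more. A directly attached phenyl or a cyclohexyloxy group at this place would separate the two.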